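A few compounds are considered here, and "the series" means these few. Any claim that something is new, unique, unknown or untested is made for them only; others in the source may bear on it.

Measured so far:
compound 1 `COc1cc(N/C=C\C(=O)c2cn(-c3ccccc3)nc2-c2ccc(Cl)cc2)cc(OC)c1OC` — in a functional assay on PC-3 cells (Homo sapiens) for antiproliferative activity, read by MTT assay, with a stated time of 48 h (on this read-out lower numbers stand for stronger inhibition and higher numbers for weaker inhibition), compound 1 gives 9980 nM
compound 2 `COc1ccc(-c2nn(-c3ccccc3)cc2C(=O)/C=C\Nc2ccc(O)cc2)cc1` — in this assay compound 2 gives 1980 nM

Compound 2 holds the lowest of the two numbers; compound 1 sits higher, beyond the scatter. Compound 3 `COc1ccc(-c2nn(-c3ccccc3)cc2C(=O)/C=C\Nc2cc(OC)c(OC)c(OC)c2)cc1` carries 3,4,5-trimethoxyphenyl in place of 4-hydroxyphenyl on an amine nitrogen. Among the compounds with values here, no measured pair differs in this one place only. Compound 1, which also bears a 3,4,5-trimethoxyphenyl on the amine nitrogen, shows 9980 nM, the weaker number. The step of a 2.5-fold higher number from compound 2 to compound 3 (0.40 log units; beyond the scatter) is therefore expected to run toward weaker inhibition, beyond the scatter. Compound 3 is expected near 5000 nM, within 1500 nM to 15000 nM.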

Compound 3, half-maximal inhibitory concentration: 18900 nM
Compound 3: middle estimate off by 3.8-fold (0.58 log units), on the low side; the measured number lies above the stated range.
By their numbers in this assay, from the lowest: compound 2; then compounds 1 and 3 (each within the scatter of the next).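

Within the data shown here, on the amine nitrogen, 3,4,5-trimethoxyphenyl in place of 4-hydroxyphenyl gives in this assay a 9.5-fold higher number from compound 2 to compound 3 (0.98 log units; beyond the scatter) and so runs toward weaker inhibition, the first one-place reading at this position. Methoxy in place of chloro on an aromatic carbon gives a 1.9-fold higher number from compound 1 to compound 3 (0.28 log units; within the scatter) and does not separate these two compounds. No measurement is available that accounts for either reading.

Still open, on these data alone, is where plain phenyl or 4-methoxyphenyl on the amine nitrogen would fall relative to compound 2 and compound 3. Also open, as far as these compounds go, is what an amine or a carboxylic acid in place of the hydroxy group of compound 2 would give.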